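Swapping Methoxy for Bromo in a Cytotoxicity Series

The source may hold more compounds than are shown below. What is called first, only, known or untested is meant among the compounds shown, and "the series" means these compounds.

Of the compounds shown here, three sharing one core have been tested in a functional assay on HeLa cells (Homo sapiens) for cytotoxicity, read by sulforhodamine B assay, with a stated time of 48 h; a lower number here means a stronger inhibitor, a higher number a weaker inhibitor. Compound 1 `CC1=C(/C=C/C(=O)/C=C/c2ccc(Cl)cc2)C(C)(C)CCC1` gives 33200 nM, compound 2 `CC1=C(/C=C/C(=O)/C=C/c2ccc(F)cc2)C(C)(C)CCC1` gives 32200 nM, and compound 3 `COc1ccccc1/C=C/C(=O)/C=C/C1=C(C)CCCC1(C)C` gives 88200 nM, the highest of the three numbers. Among the compounds with values here, the only single-point step measured so far, a 1.0-fold lower number from compound 1 to compound 2 (0.01 log units; within the scatter), lies within the scatter. Compound 4 `CC1=C(/C=C/C(=O)/C=C/c2ccccc2Br)C(C)(C)CCC1` differs from compound 3 by bromo in place of methoxy on an aromatic carbon. Within the data shown here, no measured step exchanges a methoxy for a halogen, so the halogen swap offers little direct guidance; compounds 1 and 2, each carrying a halogen, show lower numbers than compound 3. A moderate fall is therefore expected, a 2.2-fold lower number from compound 3 to compound 4 (0.34 log units; beyond the scatter), with wide uncertainty. Compound 4 is estimated at 40000 nM, between 15000 nM and 100000 nM.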

Compound 4, half-maximal inhibitory concentration: 57900 nM
Estimate against measurement, compound 4: 1.4-fold (0.16 log units) below; the range from low to high includes it.
By their numbers in this assay, from the lowest: compounds 2, 1, 4 and 3 (each within the scatter of the next, the first and the last beyond it).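

On this aromatic carbon, ortho to a large group, bromo and methoxy cannot be told apart in this assay (a 1.5-fold lower number from compound 3 to compound 4 (0.18 log units; within the scatter)). The 2-bromophenyl group likewise cannot be separated from 4-fluorophenyl (a 1.8-fold higher number from compound 2 to compound 4 (0.25 log units; within the scatter)) or from 4-chlorophenyl (a 1.7-fold higher number from compound 1 to compound 4 (0.24 log units; within the scatter)), so all of these aryl changes remain within the scatter. No supporting measurement is available to explain these results.

On these data alone, whether an amine or a carboxylic acid on this aromatic carbon would give a step beyond the scatter remains open. So does whether a change to the shared core would do so.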